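A few compounds are considered here, and "the series" means these few. Any claim that something is new, unique, unknown or untested is made for them only; others in the source may bear on it.

Measured in a functional assay on MGC-803 cells (Homo sapiens) for antiproliferative activity, read by MTT assay, with a stated time of 72 h; a higher number here means a weaker inhibitor, a lower number a stronger inhibitor:

- compound 1 `CCCSc1nc(N/N=C/c2ccc(C)cc2)c2nnn(Cc3ccccc3)c2n1` gives > 64000 nM (a limit)
- compound 2 `CCCSc1nc(N/N=C/c2ccccc2Cl)c2nnn(Cc3ccccc3)c2n1` gives 10900 nM
- compound 3 `CCCSc1nc(N/N=C(\C)c2ccccc2O)c2nnn(Cc3ccc(O)cc3)c2n1` gives 7680 nM

Compound 1 gives only a limit, > 64000 nM, and not a number. Among the true numbers, compound 2 stands level with compound 3 , the two values lying within the usual scatter of each other.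

The next compound, compound 4 `CCCSc1nc(N/N=C/c2cccs2)c2nnn(Cc3ccccc3)c2n1`, has not yet been measured. Its structure differs from that of compound 2 as follows: thiophen-2-yl in place of 2-chlorophenyl on a carbon with a double bond to nitrogen. In words, thiophen-2-yl stands in place of 2-chlorophenyl on a carbon with a double bond to nitrogen.

Among the measured compounds shown here, one measured step bears on this place: an at least 5.8-fold lower number from compound 1 to compound 2 (0.76 log units; beyond the scatter), a change beyond the scatter that rests on (the limit of > 64000 nM in this assay, at which 1 of the 3 values shown sits). Given that step, a change here can matter in this assay, and a modest move toward a higher number, meaning a weaker inhibitor, is expected once 2-chlorophenyl leaves. The estimated step is a 1.5-fold higher number from compound 2 to compound 4 (0.17 log units; within the scatter). The value expected for compound 4 is 16000 nM, with an estimated range from 5000 nM to 55000 nM.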

Compound 4, half-maximal inhibitory concentration: > 64000 nM
Compound 4 ended at the assay's limit; the forecaster's own chance of this, stated with the estimate: 25%; at least 4.0-fold (0.60 log units) between middle value and limit.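

In this assay, thiophen-2-yl in place of 2-chlorophenyl on a carbon with a double bond to nitrogen gives an at least 5.8-fold higher number from compound 2 to compound 4 (0.76 log units; beyond the scatter). Earlier, only 4-methylphenyl had lost the measurable value at this place; thiophen-2-yl now does the same, so among compound 1, compound 2 and compound 4, which differ only here, 2-chlorophenyl alone gives a true number. The size of the new step is therefore only a lower bound, as it rests on a limit: the limit of > 64000 nM in this assay, at which 2 of the 4 values shown sit.

The step from compound 1 to compound 4 cannot be read, so thiophen-2-yl and 4-methylphenyl cannot be ranked against each other. The compounds shown leave open whether it is the chlorine that matters, and whether plain phenyl, 4-chlorophenyl or a ring carrying an amine or a carboxylic acid would give a true number here.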